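A few compounds are considered here, and "the series" means these few. Any claim that something is new, unique, unknown or untested is made for them only; others in the source may bear on it.

Measured compounds in a functional assay on the whole organism (uterus) with Rattus norvegicus as the target, tested at 10 uM; a lower number here means a stronger effect, a higher number a weaker effect of the compound at the concentration tested:
- compound 1, `C[C@H](Nc1nc(O)c2cc(Cl)ccc2n1)C1CCCCC1`, gives 102%
- compound 2, `Oc1nc(NCc2ccccc2)nc2ccc(Cl)cc12`, gives 94.8%
- compound 3, `C[C@@H](Nc1nc(O)c2cc(Cl)ccc2n1)c1ccccc1`, gives 120%

Compound 3 stands at the top of these three numbers; its nearest neighbour is compound 1, and compound 2 lies furthest from it, both differences beyond the scatter. Since a lower number means a stronger effect, compound 3 shows the weakest effect of the three in this assay.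

For the measured compounds named here, the only step measured in one place is a number 25.2 percentage points higher from compound 2 to compound 3 (beyond the scatter). That step adds a methyl group; it says nothing about stereochemistry.

Compound 4, `C[C@H](Nc1nc(O)c2cc(Cl)ccc2n1)c1ccccc1`, is the mirror partner of compound 3: the two compounds have the same atoms and bonds and differ only in configuration as drawn: 1 of 1 stereo elements differ; a stereocentre at a saturated chain carbon is drawn R in compound 3 and S in compound 4. Going by the values given here, no measured pair here differs only in configuration, so there is no step to lean on. An inversion of the single stereocentre may leave the number where it is or move it in either direction, and the measured compounds give no guide to which. The expectation is therefore a step of a number 15 percentage points lower from compound 3 to compound 4 (beyond the scatter), with wide uncertainty, placing compound 4 near the middle of the measured range.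

For compound 4 in this assay the estimate is 105%, with a range from 85% to 125%.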

Compound 4, a percentage reported as activity, at one concentration (the size of the read-out at that concentration, not a potency): 92.4%
Compound 4: middle estimate off by 12.6 percentage points, on the high side; low and high end bracket the measured number.
By their numbers in this assay, from the lowest: compounds 4, 2 and 1 (each within the scatter of the next); then compound 3.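

Configuration at the saturated chain carbon that carries the methyl matters in this assay: inverting this single stereocentre gives a number 27.6 percentage points lower from compound 3 to compound 4 (beyond the scatter), and the step can be traced to the arrangement in space at that carbon alone because nothing else changes, as shown by this: the fact that compounds 3 and 4 differ only in the configuration as drawn

The earlier methyl step therefore belongs to the form drawn R and does not describe the methyl group as such, since with the form drawn S, methyl in place of hydrogen gives a number 2.4 percentage points lower from compound 2 to compound 4 (within the scatter). In that same form, phenyl in place of cyclohexyl gives a number 9.6 percentage points lower from compound 1 to compound 4 (within the scatter), so neither change moves the number beyond the usual scatter in this configuration.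

The mirror partner of compound 1 is absent from the compounds shown, so it remains open whether inversion matters in the same way when cyclohexyl replaces phenyl. Going by these compounds, it is also open how an ethyl group, a longer chain or a carboxylic acid in place of the methyl at this carbon would behave in either configuration.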